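The source may report more compounds than this note shows. Statements on the series, on what has been measured and on what is new or still open speak of the compounds shown alone.

Within the data shown here, compound 1 `C=CCn1c(=O)/c(=C\c2cccc(Cl)c2)[nH]c(=O)/c1=C\c1ccccc1OC` is the only member of this small set with a number to its name. In a functional assay on MCF7 cells (Homo sapiens) for cytotoxicity, read by CCK-8 assay, with a stated time of 72 h (a lower number here means a stronger inhibitor, a higher number a weaker inhibitor), compound 1 gives 5200 nM. Compound 2 `COc1ccccc1/C=c1/[nH]c(=O)/c(=C\c2cccc(Cl)c2Cl)[nH]c1=O` is reported in this assay as "not active" (no number reported), with no number attached, so it only shows that compounds of this family can fall outside the range the assay reports. Compound 3 `C=CCn1c(=O)/c(=C\c2cc(Br)ccc2F)[nH]c(=O)/c1=C\c1ccccc1OC` has not yet been measured in this assay. It differs from compound 1 in one place: 5-bromo-2-fluorophenyl in place of 3-chlorophenyl on a double-bonded chain carbon bound to an aromatic carbon. Among the measured compounds shown here, no step between two measured compounds of this kind is available, so the size of this change cannot be read off from anything measured here and has to be guessed. The expectation is that the step from compound 1 to compound 3 stays within the usual scatter of the assay, a 1.2-fold higher number from compound 1 to compound 3 (0.06 log units; within the scatter), with no clear direction either way. On that basis compound 3 is estimated at 6000 nM in this assay, with a range from 2000 nM to 20000 nM.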

Compound 3, half-maximal inhibitory concentration: 28100 nM
Compound 3: middle estimate off by 4.7-fold (0.67 log units), on the low side; the measured number lies above the stated range.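

Among these compounds, replacing 3-chlorophenyl with 5-bromo-2-fluorophenyl on a double-bonded chain carbon bound to an aromatic carbon gives the first change in this set that can be read as a number. In this assay it produces a 5.4-fold higher number from compound 1 to compound 3 (0.73 log units; beyond the scatter) and so moves toward a weaker inhibitor, which shows that this position is not indifferent to what the aromatic ring carries. Nothing available explains this loss, so the step stands as an observation without a reason attached.

Because the chlorine leaves while a fluorine and a bromine enter in the same step, this single pair cannot show whether the bromine, the fluorine or the absence of the chlorine matters most, and a ring carrying only one of these new halogens would be needed to separate them. From the compounds shown here alone, it also remains open whether this position accepts anything other than a halogen, such as an amine or a carboxylic acid on that ring, and whether any such group could bring the number below that of compound 1.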